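The compounds below may be only part of what the source reports. "The series", "measured", "known", "first", "only" and "open" are said of these compounds alone.

In an ADME assay on Vero cells (Chlorocebus sabaeus) for cytotoxicity, read by MTT assay (on this read-out lower numbers stand for stronger inhibition and higher numbers for weaker inhibition), compound 1 (`CCCCCCC(C)C(=O)OCC(C)(C)CC1=C(O)C(=O)c2ccccc2C1=O`) gives 450 nM and compound 2 (`CCCCCCCCCC(=O)OCC(C)(C)CC1=C(O)C(=O)c2ccccc2C1=O`) gives 203000 nM as the higher of the two numbers. Compound 3 (`CCCCCCCCCCCCCCCCCC(=O)OCC(C)(C)CC1=C(O)C(=O)c2ccccc2C1=O`) differs from compound 2 through octyl in place of hydrogen on a saturated chain carbon, nine bonds along the chain from a carbonyl carbon and so carries a longer chain. For the measured compounds named here, the only measured step is a 450-fold higher number from compound 1 to compound 2 (2.65 log units; beyond the scatter) for nonyl in place of 1-methylheptyl on a carbonyl carbon. That step is large, but it swaps a branched chain for a straight one and does not lengthen the chain, so it bears only loosely here. The expected step of a 1.0-fold lower number from compound 2 to compound 3 (0.01 log units; within the scatter) in this assay is therefore none beyond the scatter, though this is uncertain. For compound 3 the estimate is 200000 nM with an expected range from 40000 nM to 600000 nM in this measurement.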

Compound 3, half-maximal inhibitory concentration: 15500 nM
The estimate for compound 3 lay 13-fold (1.11 log units) above the measured number, outside the stated range (below it).
By their numbers in this assay, from the lowest: compound 1; then compound 3; then compound 2.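

In this assay, octyl in place of hydrogen on a saturated chain carbon, nine bonds along the chain from a carbonyl carbon, gives a 13-fold lower number from compound 2 to compound 3 (1.12 log units; beyond the scatter). The earlier step swapped a branched chain for a straight one, whereas this one shows that lengthening the straight chain alone moves the number beyond the scatter, towards stronger inhibition. Nothing available explains this shift. Two straight chains cannot show whether the number falls steadily with length or how a still longer chain behaves. On these data alone, whether an amine or a carboxylic acid on this chain would shift the number also stays open.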